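Swapping methoxy for nitro on a low-toxicity series

This account rests on a few compounds, and the source may have more. Where it says the series, first, only, none or still open, it means among the compounds named here.

Compound 1 `COc1ccc(CN(C)c2nc(C(C)c3c(Cl)cccc3Cl)c(C)c(=O)[nH]2)cc1`: in an ADME assay on TZM cells (Homo sapiens) for cytotoxicity, read by WST assay, with a stated time of 2 days (on this read-out lower numbers stand for higher toxicity in this test and higher numbers for lower toxicity in this test), compound 1 gives > 100000 nM, which is a limit of the assay rather than a number.
Compound 2 `Cc1c(C(C)c2c(Cl)cccc2Cl)nc(N(C)Cc2ccc([N+](=O)[O-])cc2)[nH]c1=O`: in this assay compound 2 gives > 50000 nM, again a limit of the assay.
Among the measured compounds shown here, compound 3 `COc1ccc(CN(C)c2nc(C(C)c3c(F)cccc3F)c(C)c(=O)[nH]2)cc1`: in this assay compound 3 gives 88800 nM, the only plain number among the three.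

The change from compound 1 to compound 2 is nitro in place of methoxy on an aromatic carbon. Its effect in this assay is a step that the two limits leave unreadable from compound 1 to compound 2, unreadable because the limit of > 100000 nM in this assay, at which 1 of the 3 values shown sits, and the limit of > 50000 nM in this assay, at which 1 of the 3 values shown sits, are both limits and not numbers. The two cores differ by 2,6-difluorophenyl in place of 2,6-dichlorophenyl on a saturated chain carbon bound to an aromatic carbon and a saturated chain carbon, and that step gives an at least 1.1-fold lower number from compound 1 to compound 3 (0.05 log units; that floor lies within the scatter), a step that the usual scatter of repeated measurements would cover.

Compound 4 `Cc1c(C(C)c2c(F)cccc2F)nc(N(C)Cc2ccc([N+](=O)[O-])cc2)[nH]c1=O` has not been measured. For the measured compounds named here, it differs from compound 3 by nitro in place of methoxy on an aromatic carbon, the same change at the same place as the one from compound 1 to compound 2. For compound 4 the step is expected to be a 1.0-fold lower number from compound 3 to compound 4 (0.02 log units; within the scatter), a small one, because an at least 1.1-fold lower number from compound 1 to compound 3 (0.05 log units; that floor lies within the scatter) shows the core change hardly moves the read-out and because a step that the two limits leave unreadable from compound 1 to compound 2 gives no sign that the methoxy-to-nitro change moves it either. Compound 4 is therefore estimated at 85000 nM in this assay, with a plausible range from 40000 nM to 200000 nM, and a real chance that only a limit is reported.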

Compound 4, half-maximal cytotoxic concentration: > 50000 nM
Compound 4: only a limit was reported (the forecaster's own chance of this, stated with the estimate: 50%); the middle value does not contradict the limit.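

Compound 4 gives > 50000 nM in this assay, which is a limit of the assay and not a number. Among the compounds shown here, neither the step from compound 3 to compound 4 nor the one from compound 2 to compound 4 can be read, so this result yields no new step. The compounds shown leave open whether nitro in place of methoxy changes the read-out at all, with either 2,6-dichlorophenyl or 2,6-difluorophenyl on the core.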